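The source may report more compounds than this note shows. Statements on the series, on what has been measured and on what is new or still open speak of the compounds shown alone.

Working notes on the series, read in a functional assay on MV4-11 cells (Homo sapiens) for inhibition, read by resazurin assay, with a stated time of 72 h; a lower number here means a stronger inhibitor of growth, a higher number a weaker inhibitor of growth. Among the compounds with values here, compound 1 (`COCCOc1nc(C)c(-c2ccnc(Nc3ccc(OC)cc3OC)n2)s1`) gives 1980 nM, and compound 2 (`CNc1nc(C)c(-c2ccnc(Nc3ccc(OC)cc3OC)n2)s1`) gives 300 nM, the lower of the only two numbers so far. Compound 3 (`COc1ccc(Nc2nccc(-c3sc(OC)nc3C)n2)c(OC)c1`) is not yet measured and has methoxy in place of methylamino on an aromatic carbon of the five-membered aromatic ring with 1 nitrogen and 1 sulfur: methoxy in place of methylamino on an aromatic carbon. Within the data shown here, one measured step bears on this change: a 6.6-fold lower number from compound 1 to compound 2 (0.82 log units; beyond the scatter), with methylamino in place of 2-methoxyethoxy on an aromatic carbon. Among the measured compounds shown here, compound 3 carries methoxy where compound 1 carries 2-methoxyethoxy, and no measured pair separates these two groups. A higher number than that of compound 2 is therefore expected, beyond the scatter but possibly smaller than the measured step. The expected step is a 3.0-fold higher number from compound 2 to compound 3 (0.48 log units; beyond the scatter). For compound 3 the estimated value is 900 nM, with an expected range of 320 nM to 2600 nM.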

Compound 3, concentration for 50% growth inhibition: 1400 nM
Compound 3: the middle estimate sits 1.6-fold (0.19 log units) below what was measured, within the range that was stated.
By their numbers in this assay, from the lowest: compound 2; then compounds 3 and 1 (each within the scatter of the next).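

In this assay, a 4.7-fold higher number from compound 2 to compound 3 (0.67 log units; beyond the scatter), so at this position, on an aromatic carbon next to the ring nitrogen and next to the ring sulfur, methylamino now stands apart from methoxy, a group of the same heavy-atom count with no hydrogen-bond donor. The other new step, a 1.4-fold lower number from compound 1 to compound 3 (0.15 log units; within the scatter), does not separate methoxy from 2-methoxyethoxy, so compound 2 stands apart from both oxygen-linked groups, while the added methoxymethyl shows no effect beyond the scatter. No measurement on hand explains the difference between methylamino and these groups. On these data alone, it remains open whether the lower number of compound 2 depends on the amine hydrogen, a question that dimethylamino at this position would address. Also open, as far as these compounds go, is whether a longer amine such as ethylamino or 2-methoxyethylamino would keep that number.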